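Diaryl urea series: chloro for trifluoromethyl on the terminal ring

This account rests on a few compounds, and the source may have more. Where it says the series, first, only, none or still open, it means among the compounds named here.

Compound 1 `COc1cc2cc(Oc3ccc(NC(=O)Nc4cccc(C(F)(F)F)c4)cc3)c(C)nc2cc1OC` gives 26300 nM in a functional assay on RXF 393 cells (Homo sapiens) for inhibition, read by sulforhodamine B assay, with a stated time of 48 h; a higher number here means that more compound is tolerated, a lower number that less compound is tolerated. Compound 2 `COc1cc2cc(Oc3ccc(NC(=O)Nc4ccc(Cl)c(C(F)(F)F)c4)cc3)c(C)nc2cc1OC`, which adds a chloro group to the terminal ring, gives 15000 nM in this assay; the step of a 1.8-fold lower number from compound 1 to compound 2 (0.24 log units; within the scatter) is within the scatter. Within the data shown here, compound 2 therefore holds the lowest of the two numbers so far, with compound 1 as its only neighbour and the two not separable by the measurement.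

Compound 3 `COc1cc2cc(Oc3ccc(NC(=O)Nc4ccc(Cl)c(Cl)c4)cc3)c(C)nc2cc1OC` is to be measured in this assay. It differs from compound 2 by chloro in place of trifluoromethyl on an aromatic carbon, so the ring keeps both substituents and only the group ortho to the retained chloro is exchanged. Among the measured compounds shown here, no measured step changes a trifluoromethyl group into a chloro group; the one step available, a 1.8-fold lower number from compound 1 to compound 2 (0.24 log units; within the scatter), concerns a different exchange and was itself within the scatter. On this basis no step beyond the scatter is expected for no change at the digits printed from compound 2 to compound 3 (within the scatter), in either direction. Compound 3 is estimated at 15000 nM in this assay, with a range from 6000 nM to 40000 nM.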

Compound 3, concentration lethal to 50% of the cells: 65700 nM
Beside the measured number, compound 3's estimate is 4.4-fold (0.64 log units) below it, outside the stated range (above it).
By their numbers in this assay, from the lowest: compounds 2 and 1 (each within the scatter of the next); then compound 3.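

Trifluoromethyl at this carbon, ortho to a chloro group and meta to a large group, proves to matter in this assay: exchanging it for chloro gives a 4.4-fold higher number from compound 2 to compound 3 (0.64 log units; beyond the scatter), whereas the added chloro examined earlier gave only a 1.8-fold lower number from compound 1 to compound 2 (0.24 log units; within the scatter). The 3,4-dichlorophenyl group also separates from the 3-(trifluoromethyl)phenyl group, with a 2.5-fold higher number from compound 1 to compound 3 (0.40 log units; beyond the scatter), so among these three compounds the one without trifluoromethyl is the one that stands apart, at the higher number, while compound 1 and compound 2 stay unresolved from each other. Nothing measured here beyond these numbers bears on the result, so the step stands as an observation only.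

The compounds shown leave open how the number responds to a methyl, a methoxy, a nitrile or an amine at this same carbon, and so whether trifluoromethyl is unusual there or chloro is. They also leave open whether the exchange gives a step of similar size when the chloro group ortho to this position is replaced by hydrogen, or in any cell line other than this one.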